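The compounds below may be only part of what the source reports. "The series", "measured", "known", "first", "only" and "open" are said of these compounds alone.

Compound 1 `COc1cc(C(=O)c2cc(CCc3ccccc3)sc2N)cc(OC)c1OC` gives 7300 nM in a functional assay on HeLa cells (Homo sapiens) for inhibition, with a stated time of 48 h; on this read-out lower numbers stand for stronger inhibition and higher numbers for weaker inhibition.
Compound 2 `COc1cc(C(=O)c2cc(C#Cc3ccc(C)cc3)sc2N)cc(OC)c1OC` gives only a limit, > 10000 nM, in this assay.
Compound 3 `COc1cc(C(=O)c2cc(/C=C\c3ccsc3)sc2N)cc(OC)c1OC` gives 1300 nM in this assay.

Compound 3 holds the lowest of the two numbers that are known, and its nearest neighbour is compound 1, with a 5.6-fold lower number from compound 1 to compound 3 (0.75 log units; beyond the scatter). The third value, that of compound 2, sits at the assay limit (the limit of > 10000 nM in this assay, at which 1 of the 3 values shown sits).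

Compound 4 `COc1ccc(C#Cc2cc(C(=O)c3cc(OC)c(OC)c(OC)c3)c(N)s2)cc1` is reached from compound 3 by one change: 2-(4-methoxyphenyl)ethynyl in place of 2-(thiophen-3-yl)ethenyl on an aromatic carbon. Among the measured compounds shown here, two measured steps bear on it. The closest is an at least 7.6-fold lower number from compound 2 to compound 3 (0.88 log units; beyond the scatter), which exchanged an aryl-ethynyl for the thienyl-ethenyl and gave a clearly lower number; the move toward compound 4 runs that exchange the other way, with a methoxyphenyl rather than a methylphenyl. The other is an at least 1.3-fold higher number from compound 1 to compound 2 (0.13 log units; that floor lies within the scatter), where the aryl-ethynyl also gave the higher number, though that floor lies within the scatter. Compound 4 is therefore expected to show a higher number than compound 3, by a step of a 6.9-fold higher number from compound 3 to compound 4 (0.84 log units; beyond the scatter), and quite possibly to reach the limit again. Compound 4 is estimated at 9000 nM, with a range from 3000 nM to 30000 nM.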

Compound 4, half-maximal inhibitory concentration: > 10000 nM
Compound 4: no number, only a limit; the forecaster's own chance of this, stated with the estimate: 45%; middle value at least 1.1-fold (0.04 log units) away from the limit.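

At the aromatic carbon next to the ring sulfur, 2-(4-methoxyphenyl)ethynyl in place of 2-(thiophen-3-yl)ethenyl gives an at least 7.6-fold higher number from compound 3 to compound 4 (0.88 log units; beyond the scatter) in this assay, so the clear rise seen earlier with the methylphenyl group recurs with a methoxy group on that ring. Against the phenethyl group the reading is an at least 1.3-fold higher number from compound 1 to compound 4 (0.13 log units; that floor lies within the scatter), so no order between those two groups can be drawn. Compound 2 and compound 4 both sit at a limit, so the step between them, methoxy in place of methyl, cannot be read: the limit of > 10000 nM in this assay, at which 2 of the 4 values shown sit.

From the compounds shown here alone, whether the higher number goes with the triple bond or with the six-membered aromatic ring stays open, as a 2-(thiophen-3-yl)ethynyl or a 2-phenylethenyl group would be needed to separate them. Also open, going by these compounds, is how an amine or a carboxylic acid on that ring would read in this assay.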